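Swapping Chloro for Methyl on the Formyl Analogue

The source may report more compounds than this note shows. Statements on the series, on what has been measured and on what is new or still open speak of the compounds shown alone.

Compound 3 `O=Cc1c(-c2ccc(Cl)cc2)nc2sc(Cc3ccc(Cl)cc3)nn12` is the only one of the three measured compounds with a numerical result: in a functional assay on HeLa cells (Homo sapiens) for cytotoxicity, with a stated time of 72 h (a lower number here means a stronger inhibitor, a higher number a weaker inhibitor), compound 3 gives 16000 nM. Compound 1 `Clc1ccc(Cc2nn3c(Br)c(-c4ccc(Cl)cc4)nc3s2)cc1` reaches only a limit of the assay, since in this assay compound 1 gives > 250000 nM. Compound 2 `Cc1ccc(-c2nc3sc(Cc4ccc(Cl)cc4)nn3c2Br)cc1` likewise stands at a limit, with > 250000 nM in this assay. Two of the three values thus share (the limit of > 250000 nM in this assay, at which 2 of the 3 values shown sit), and compound 3 alone stands at a number.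

Two measured steps exist. The step of an at least 15-fold lower number from compound 1 to compound 3 (1.19 log units; beyond the scatter) shows what formyl in place of bromo did. The step that the two limits leave unreadable from compound 1 to compound 2 concerns the very change now considered, methyl in place of chloro, but both of its values are limits and its size cannot be read.

Compound 4 `Cc1ccc(-c2nc3sc(Cc4ccc(Cl)cc4)nn3c2C=O)cc1` differs from compound 3 by methyl in place of chloro on an aromatic carbon. Because a step that the two limits leave unreadable from compound 1 to compound 2 is unreadable, there is no measured ground to expect a step beyond the scatter in this assay in either direction, so the number of compound 3 is the best guide. Compound 4 is therefore expected at 16000 nM, within a range from 5000 nM to 60000 nM, which means an expected step of no change at the digits printed from compound 3 to compound 4 (within the scatter).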

Compound 4, half-maximal inhibitory concentration: 21000 nM
The estimate for compound 4 lay 1.3-fold (0.12 log units) below the measured number, within the range that was stated.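

Going by these compounds alone, with the formyl group in place, the change from 4-chlorophenyl to 4-methylphenyl can be read in this assay for the first time, as the bromo pair, with both values at a limit, could not show it: the step is a 1.3-fold higher number from compound 3 to compound 4 (0.12 log units; within the scatter). At this position on the formyl core, chloro and methyl thus cannot be told apart in this read-out. Within the data shown here, the change from bromo to formyl, so far seen only with 4-chlorophenyl, now also gives a large step with 4-methylphenyl, namely an at least 11-fold lower number from compound 2 to compound 4 (1.07 log units; beyond the scatter), and both steps lie beyond the scatter, although their sizes cannot be set against each other: the same change on two cores in this assay, an at least 15-fold lower number (1.19 log units; beyond the scatter) from compound 1 to compound 3 and an at least 11-fold lower number (1.07 log units; beyond the scatter) from compound 2 to compound 4; the limit leaves it open whether they differ.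

The compounds shown leave open whether a group of another kind at this position, such as an amine or a carboxylic acid, would depart from the values of chloro and methyl, and whether anything other than formyl, such as hydroxymethyl or a nitrile, would carry the same gain over bromo. How far the bromo compounds actually lie from the formyl compounds also stays unknown, with only a limit on their side: the limit of > 250000 nM in this assay, at which 2 of the 4 values shown sit.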